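This account rests on a few compounds, and the source may have more. Where it says the series, first, only, none or still open, it means among the compounds named here.

Measured in a functional assay on HUVEC cells (Homo sapiens) for antiproliferative activity, read by MTT assay, with a stated time of 24 h; on this read-out lower numbers stand for stronger inhibition and higher numbers for weaker inhibition:

- Compound 1 `COc1cc(OC)c(-c2coc3cc(OCc4ccccc4)ccc3c2=O)cc1OC`: 9750 nM
- Compound 2 `COc1cccc(C(=O)Oc2ccc3c(=O)c(-c4cc(OC)c(OC)cc4OC)coc3c2)c1`: > 10000 nM (a limit of the assay, not a number)
- Compound 3 `COc1cc(OC)c(-c2coc3cc(OCc4ccccc4F)ccc3c2=O)cc1OC`: 4300 nM

Of the two actual numbers in this assay, the lower belongs to compound 3, at 4300 nM, while compound 1 gives 9750 nM. Compound 4 `COc1cc(OC)c(-c2coc3cc(OCc4ccccc4C)ccc3c2=O)cc1OC` follows from compound 3 by placing methyl in place of fluoro on an aromatic carbon, ortho to a large group (methyl in place of fluoro on an aromatic carbon), so that (2-fluorobenzyl)oxy becomes (2-methylbenzyl)oxy.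

Among the compounds with values here, no measured step makes this exchange. The nearest is a 2.3-fold lower number from compound 1 to compound 3 (0.36 log units; beyond the scatter), which puts fluoro in place of hydrogen on that same carbon. The other steps, an at least 1.0-fold higher number from compound 1 to compound 2 (0.01 log units; that floor lies within the scatter) and an at least 2.3-fold lower number from compound 2 to compound 3 (0.36 log units; beyond the scatter), replace the whole group on the oxygen and say less here. A step of no more than modest size is therefore expected in this assay, leaning towards a higher number, with the value staying near the span set by the two benzyl ethers.

The expected change is a 1.3-fold higher number from compound 3 to compound 4 (0.11 log units; within the scatter). For compound 4 the estimated value is 5500 nM, with an expected range of 2500 nM to 10000 nM.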

Compound 4, half-maximal inhibitory concentration: 4830 nM
Beside the measured number, compound 4's estimate is 1.1-fold (0.06 log units) above it, within the range that was stated.
By their numbers in this assay, from the lowest: compounds 3 and 4 (each within the scatter of the next); then compound 1. At a limit, above all of these: compound 2.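

In (this assay) this aromatic carbon, ortho to a large group, now carries a third substituent, and methyl in place of fluoro gives no change beyond the scatter (a 1.1-fold higher number from compound 3 to compound 4 (0.05 log units; within the scatter)), so the two groups cannot be told apart here. Methyl in place of hydrogen on the same carbon gives a modest step (a 2.0-fold lower number from compound 1 to compound 4 (0.31 log units; beyond the scatter)), so the gain seen earlier with fluoro is shared by compound 3 and compound 4. With 2-methylbenzyl in place of (3-methoxyphenyl)carbonyl on the oxygen, the step (an at least 2.0-fold lower number from compound 2 to compound 4 (0.31 log units; beyond the scatter)) is only a floor, as compound 2 stands at a limit of the assay and not at a number: the limit of > 10000 nM in this assay, at which 1 of the 4 values shown sits.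

On these data alone, whether a methoxy group, a chlorine or an amine on this carbon would read like fluoro and methyl remains open. So does how either group would read on the other carbons of that ring.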